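This account rests on a few compounds, and the source may have more. Where it says the series, first, only, none or still open, it means among the compounds named here.

Compound 3, `Cc1noc(-c2nc(C)c3c(c2N)C(=O)N(CC2CCNCC2)C3=O)n1`, gives 160000 nM in a physicochemical assay for solubility, using the shake flask method, in simulated intestinal fluid, measured as kinetic solubility, with a stated time of 2 h, at 25 degrees C, at pH 6.5 (a lower number here means a less soluble compound, a higher number a more soluble compound), the highest of the three numbers in hand. Compound 2, `CNC(=O)c1nc(C)c2c(c1N)C(=O)N(Cc1ccccc1)C2=O`, gives 41000 nM in this assay, and compound 1, `COC(=O)c1nc(C)c2c(c1N)C(=O)N(Cc1ccccc1)C2=O`, gives 7400 nM. Among the compounds with values here, the one step among the measured compounds, a 5.5-fold higher number from compound 1 to compound 2 (0.74 log units; beyond the scatter), concerns a change at a carbonyl carbon and does not touch the part of the molecule altered here.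

Compound 4, `Cc1noc(-c2nc(C)c3c(c2N)C(=O)N(Cc2ccc(Cl)cn2)C3=O)n1`, differs from compound 3 by 5-chloropyridin-2-yl in place of piperidin-4-yl on a saturated chain carbon bound to an amide-type nitrogen in a ring. Within the data shown here, no measured pair isolates this change, so the expectation rests on the values alone: compounds 1 and 2, which carry a six-membered aromatic ring on the saturated chain carbon bound to the amide-type nitrogen in the ring, both lie well below compound 3, though each also differs from compound 3 elsewhere. On that basis compound 4 is expected to fall below compound 3, with an estimated step of an 11-fold lower number from compound 3 to compound 4 (1.03 log units; beyond the scatter). Compound 4 is therefore estimated at 15000 nM in this assay, within a range from 3000 nM to 60000 nM.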

Compound 4, solubility: < 5000 nM
Compound 4 ended at the assay's limit; the forecaster's own chance of this, stated with the estimate: 5%; middle value at least 3.0-fold (0.47 log units) away from the limit.
By their numbers in this assay, from the lowest: compound 1; then compound 2; then compound 3. At a limit, below all of these: compound 4.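

Replacing piperidin-4-yl with 5-chloropyridin-2-yl on a saturated chain carbon bound to an amide-type nitrogen in a ring gives an at least 32-fold lower number from compound 3 to compound 4 (1.50 log units; beyond the scatter). This is the first step shown at this position, and it is large, whereas the only earlier step concerned a change at a carbonyl carbon. In this assay compound 4 gives a limit rather than a number, so the full size of the step stays unknown: the limit of < 5000 nM in this assay, at which 1 of the 4 values shown sits.

The compounds shown leave open whether the step follows the loss of the saturated piperidine ring or the entry of the chlorine, and a cyclohexyl or an unsubstituted pyridin-2-yl group on the same carbon would separate the two. As far as these compounds go, how a morpholine or a carboxylic acid at this position would read in this assay also remains open.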